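The source may hold more compounds than are shown below. What is called first, only, known or untested is meant among the compounds shown, and "the series" means these compounds.

Working notes on the series. Among the measured compounds shown here, compound 1 `Cc1cccc(-c2noc(C3CN(S(=O)(=O)c4cccc(C)c4)C3)n2)c1`, the only member with a sulfonyl linkage on the ring nitrogen, gives 650 nM in an assay on HEK293 cells for negative allosteric modulation of metabotropic glutamate receptor 5 (Homo sapiens), read by FLIPR; on this read-out higher numbers stand for weaker inhibition and lower numbers for stronger inhibition. Compound 2 `CC1CCC(C(=O)N2CC(c3nc(-c4cccc(Cl)c4)no3)C2)CC1` carries an amide in the same place; in this assay compound 2 returns only a limit, > 10000 nM, not a number. Compound 3 `O=C(C1CCC(C(F)(F)F)CC1)N1CC(c2nc(-c3cccc(F)c3)no2)C1` likewise returns only a limit in this assay, > 10000 nM. Compound 2 therefore stands at the weak end of the numbers seen so far, together with compound 3 at the limit of > 10000 nM in this assay, at which 2 of the 3 values shown sit, with no measured number of its own to build on.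

Compound 4 `O=C(C1CCC(F)(F)CC1)N1CC(c2nc(-c3cccc(Cl)c3)no2)C1` is not yet measured. The change is 4,4-difluorocyclohexyl in place of 4-methylcyclohexyl on a carbonyl carbon. For the measured compounds named here, no step between measured compounds isolates such a change, and compound 3, which also carries a fluorinated cyclohexyl amide, sits at the same limit as compound 2. Nothing in the data points to a gain beyond the scatter in this assay. The expectation for compound 4 is accordingly a value around 12000 nM, within 4000 nM to 40000 nM, most likely reported again as a limit. The expected step that the limit leaves unreadable from compound 2 to compound 4 is thus essentially none.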

Compound 4, half-maximal inhibitory concentration: > 10000 nM
Compound 4 gave a limit, no number; the forecaster's own chance of this, stated with the estimate: 65%; the middle value lies beyond the limit too.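

Compound 2 and compound 4 each return only a limit in this assay, so no step can be read for 4,4-difluorocyclohexyl in place of 4-methylcyclohexyl. The compounds shown leave open how compound 2, compound 3 and compound 4 rank against one another, and whether any amide here gives a measurable value.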